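Bromo for Methyl on Two Related Cores

This account rests on a few compounds, and the source may have more. Where it says the series, first, only, none or still open, it means among the compounds named here.

Compound 1: `COC(=O)[C@@]1(C)CCC=C2[C@@H]1CC[C@@H](C)[C@]2(C)Cc1c(C)[nH]c2c(C)cccc12`, 15000 nM
Compound 2: `COC(=O)[C@@]1(C)CCC=C2[C@@H]1CC[C@@H](C)[C@]2(C)Cc1c(C)[nH]c2c(Br)cccc12`, 25000 nM
Compound 3: `COC(=O)[C@@]1(C)CC[C@@H]2C3=C1CC[C@@H](C)[C@]3(C)C[C@@H]1c3cccc(C)c3N[C@H]21`, 31000 nM

All three compounds were tested in a functional assay on SW1573 cells (Homo sapiens) for inhibition, read by sulforhodamine B assay, with a stated time of 48 h; a higher number here means a weaker inhibitor of growth, a lower number a stronger inhibitor of growth. Compound 1 gives 15000 nM and compound 2 gives 25000 nM. The two differ in one place, described as follows: bromo in place of methyl on an aromatic carbon. The step is a 1.7-fold higher number from compound 1 to compound 2 (0.22 log units; within the scatter).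

Compound 3 gives 31000 nM in this assay. It shares much with compound 1, but the difference between the two cores is not broken down here. Its value and that of compound 2 lie within the scatter of each other, while compound 1 gives a lower number than compound 3 by a margin beyond the scatter.

Compound 4, `COC(=O)[C@@]1(C)CC[C@@H]2C3=C1CC[C@@H](C)[C@]3(C)C[C@@H]1c3cccc(Br)c3N[C@H]21`, has not yet been measured. It differs from compound 3 in this way: bromo in place of methyl on an aromatic carbon. This is the same kind of change as that from compound 1 to compound 2, but not the same: in compound 4 the aromatic carbon belongs to a fused or bridged system of five rings, whereas in compound 2 it belongs to a system of two rings.

In this assay the step from compound 3 to compound 4 is expected to be a 1.5-fold higher number from compound 3 to compound 4 (0.16 log units; within the scatter), resting on the step of a 1.7-fold higher number from compound 1 to compound 2 (0.22 log units; within the scatter) seen between compound 1 and compound 2. Compound 4 is therefore estimated to give 45000 nM, most likely between 20000 nM and 100000 nM.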

Compound 4, concentration for 50% growth inhibition: 44000 nM
Compound 4: the middle estimate sits 1.0-fold (0.01 log units) above what was measured; measured number inside the range.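

In this assay, bromo in place of methyl on an aromatic carbon gives a 1.4-fold higher number from compound 3 to compound 4 (0.15 log units; within the scatter). Set beside the same change on the other core, the two steps agree: the same change on two cores in this assay, a 1.7-fold higher number (0.22 log units; within the scatter) from compound 1 to compound 2 and a 1.4-fold higher number (0.15 log units; within the scatter) from compound 3 to compound 4, 1.2-fold (0.07 log units) apart, within the scatter of two such steps. This shows that, on these two cores, the change carries over in the sense that both steps are small and neither can be told apart from the ordinary spread of repeated measurements; it does not show that bromo and methyl truly differ in this assay, and two cores are too few to predict the outcome on a third.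

The compounds shown hold only methyl or bromo on this aromatic carbon, so it remains open how a chloro group, a methoxy group or an amine at the same place would read on either core. All four compounds also carry the same methyl ester, which leaves open whether a carboxylic acid or an amide in its place would change the numbers on either core, and whether the two cores would then still respond alike.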